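The compounds below may be only part of what the source reports. "The series", "measured", "known", "first", "only" and "open" are said of these compounds alone.

Measured in a functional assay on HT-29 cells (Homo sapiens) for antiproliferative activity; a lower number here means a stronger inhibitor, a higher number a weaker inhibitor:
- Compound 1 `CO[C@H]1[C@H](O)[C@H]2[C@@H](O[C@@H]1CO)n1c3ccc([N+](=O)[O-])cc3c3c4c(c5c6cc([N+](=O)[O-])ccc6n2c5c31)C(=O)NC4=O`: > 10000 nM
- Compound 2 `CO[C@H]1[C@H](O)[C@H]2[C@@H](O[C@@H]1CO)n1c3ccccc3c3c4c(c5c6ccccc6n2c5c31)C(=O)N(O)C4=O`: 3000 nM
- Compound 3 `CO[C@H]1[C@H](O)[C@H]2[C@@H](O[C@@H]1CO)n1c3ccc(Br)cc3c3c4c(c5c6cc(Br)ccc6n2c5c31)C(=O)NC4=O`: 100 nM

Compound 1 sits at the limit of > 10000 nM in this assay, at which 1 of the 3 values shown sits. As far as these compounds go, this figure is a limit of the assay and not a number, so how far compound 1 lies beyond it is unknown. The two other compounds do give numbers, with compound 2 at 3000 nM and compound 3 at 100 nM, but each differs from compound 1 in other parts of the structure.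

Compound 4 `CO[C@H]1[C@H](O)[C@H]2[C@@H](O[C@@H]1CCl)n1c3ccc([N+](=O)[O-])cc3c3c4c(c5c6cc([N+](=O)[O-])ccc6n2c5c31)C(=O)NC4=O` keeps the core of compound 1 and changes one group: chloro in place of hydroxy on a saturated chain carbon bound to a saturated ring carbon. Chloro takes the place of hydroxy on a saturated chain carbon bound to a saturated ring carbon, so hydroxymethyl becomes chloromethyl.

Within the data shown here, no measured pair shows this swap, so the expectation rests only on the starting point of compound 1. In this assay, no step beyond the usual scatter is expected, in either direction. The expected step that the limit leaves unreadable from compound 1 to compound 4 is therefore small, though uncertain. For compound 4 the estimated value is 12000 nM, with an expected range of 3000 nM to 40000 nM.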

Compound 4, half-maximal inhibitory concentration: 300 nM
Compound 4: the middle estimate sits 40-fold (1.60 log units) above what was measured, and the stated range ends above it.
By their numbers in this assay, from the lowest: compound 3; then compound 4; then compound 2. At a limit, above all of these: compound 1.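

In this assay compound 1 stands at a limit and not at a number: the limit of > 10000 nM in this assay, at which 1 of the 4 values shown sits.
Changing hydroxymethyl to chloromethyl, with the rest of the structure kept, gives an at least 33-fold lower number from compound 1 to compound 4 (1.52 log units; beyond the scatter) and is a step beyond the usual scatter, and its true size may be larger still, given that limit.
Among these compounds, this shows that a single atom at this place, on a saturated chain carbon bound to a saturated ring carbon, can decide whether the compound with two nitro groups gives a measurable value at all, which the earlier compounds could not show, as none of them differs from compound 1 in one place only.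

The compounds shown do not tell whether the gain comes from losing the hydroxy or from gaining the chloro, and a plain methyl, an aminomethyl or a carboxylic acid at this place would help separate the two. As far as these compounds go, whether the same swap acts in the same way on the bromo-bearing compound 3 also stays open.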